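A pyrazole amide in place of a hydroxyalkyl amide

This account rests on a few compounds, and the source may have more. Where it says the series, first, only, none or still open, it means among the compounds named here.

Compound 3 `CC1(C)Cc2c(sc(NC(=O)[C@H](O)C(C)(C)C)c2C(N)=O)C(C)(C)O1` carries the shared core with an amide whose carbonyl carbon bears a 1-hydroxy-2,2-dimethylpropyl group. In an assay on cells for positive allosteric modulation of Cystic fibrosis transmembrane conductance regulator variant F508del (Homo sapiens), with stated times of 10 min and 7 s, in the presence of a further agent that is not named here (a lower number here means that less compound is needed, a higher number that more compound is needed for the effect), compound 3 gives 127 nM, the highest of the two numbers obtained. Compound 1 `CC1(C)Cc2c(sc(NC(=O)c3ccccc3O)c2C(N)=O)C(C)(C)O1` gives 4 nM, and the change to the hydroxyalkyl group reads a 32-fold higher number from compound 1 to compound 3 (1.50 log units; beyond the scatter). Compound 2 `CC1(C)Cc2c(sc(NC(=O)C3CNC(=O)C3)c2C(N)=O)C(C)(C)O1` reaches only a limit of the assay, > 10000 nM. The steps of an at least 2500-fold higher number from compound 1 to compound 2 (3.39 log units; beyond the scatter) and an at least 78-fold lower number from compound 2 to compound 3 (1.89 log units; beyond the scatter) are both large. Compound 4 `Cc1cn[nH]c1C(=O)Nc1sc2c(c1C(N)=O)CC(C)(C)OC2(C)C` differs from compound 3 by 4-methyl-1H-pyrazol-5-yl in place of 1-hydroxy-2,2-dimethylpropyl on a carbonyl carbon, returning to an aromatic ring on the carbonyl carbon, as in compound 1, whose value was 4 nM. Compound 4 is therefore expected to give 30 nM, between 5 nM and 200 nM, an estimated step of a 4.2-fold lower number from compound 3 to compound 4 (0.63 log units; beyond the scatter).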

Compound 4, half-maximal effective concentration: 2 nM
For compound 4 the middle estimate is 15-fold (1.18 log units) above the measured one; the whole stated range lies above it.
By their numbers in this assay, from the lowest: compounds 4 and 1 (each within the scatter of the next); then compound 3. At a limit, above all of these: compound 2.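

In this assay, the 2-hydroxyphenyl group is not the only aromatic ring that works on this carbonyl carbon, since 4-methyl-1H-pyrazol-5-yl gives a 2.0-fold lower number from compound 1 to compound 4 (0.30 log units; within the scatter). Replacing the hydroxyalkyl group with this ring gives a 64-fold lower number from compound 3 to compound 4 (1.80 log units; beyond the scatter), so among these four compounds, the two with an aromatic ring here have the lowest numbers. The value of compound 2 is a limit of the assay, so this step is only a bound: an at least 5000-fold lower number from compound 2 to compound 4 (3.69 log units; beyond the scatter). The compounds shown leave open what the methyl group on the pyrazole contributes. On these data alone, whether an unsubstituted pyrazole or a plain phenyl ring would serve equally well also remains open.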